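Swapping the Amine on the Pyridyl-Bearing Core

The source may report more compounds than this note shows. Statements on the series, on what has been measured and on what is new or still open speak of the compounds shown alone.

Compound 3 `CCCCN(CC)c1nc(C)nc2c1n(C)c(=O)n2-c1c(C)cc(C)nc1C` sits at the top of the three numbers measured in an assay on HEK293 cells for binding affinity to corticotropin-releasing factor receptor 1 (Homo sapiens), read by radioligand binding (on this read-out lower numbers stand for stronger inhibition and higher numbers for weaker inhibition), where compound 3 gives 124 nM. Compound 1 `CCCN(CC1CC1)c1nc(C)nc2c1n(C)c(=O)n2-c1ccc(C(C)C)cc1Br` gives 5.7 nM, and compound 2 `CCCN(CC1CC1)c1nc(C)nc2c1n(C)c(=O)n2-c1c(C)cc(C)cc1C` gives 6.1 nM; the gap from either of these to compound 3 is beyond the scatter. Compound 4 `CCCN(CC1CC1)c1nc(C)nc2c1n(C)c(=O)n2-c1c(C)cc(C)nc1C` has not yet been measured. It differs from compound 3 in one place: (cyclopropylmethyl)(propyl)amino in place of butyl(ethyl)amino on an aromatic carbon. For the measured compounds named here, the amine it gains is the one carried by compounds 1 and 2. Going by the values given here, none of the measured steps alters this amine; the only single-point step, a 1.1-fold higher number from compound 1 to compound 2 (0.03 log units; within the scatter), concerns the group on the aromatic nitrogen and lies within the scatter. Compound 2 and compound 3 differ both in the amine and in that aryl group, so their two values show only that one or both of these changes account for the difference between them. Compound 4 carries the amine of compound 2 at 6.1 nM together with the aryl group of compound 3, so a step toward the numbers of compounds 1 and 2 in this assay is expected, though its size is uncertain. Compound 4 is therefore estimated at 20 nM, within 5 nM to 80 nM. The expected step is a 6.2-fold lower number from compound 3 to compound 4 (0.79 log units; beyond the scatter).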

Compound 4, inhibition constant: 113 nM
Compound 4: the middle estimate sits 5.7-fold (0.75 log units) below what was measured, and the stated range ends below it.
By their numbers in this assay, from the lowest: compounds 1 and 2 (each within the scatter of the next); then compounds 4 and 3 (each within the scatter of the next).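

In this assay, for the compounds shown here, the amine exchange on the aromatic carbon produces no step that can be told from the scatter (a 1.1-fold lower number from compound 3 to compound 4 (0.04 log units; within the scatter)), so with 2,4,6-trimethylpyridin-3-yl on the aromatic nitrogen, (cyclopropylmethyl)(propyl)amino and butyl(ethyl)amino read alike. With (cyclopropylmethyl)(propyl)amino held constant, the large steps appear at the aromatic nitrogen instead: 2,4,6-trimethylpyridin-3-yl replaces 2,4,6-trimethylphenyl (a 19-fold higher number from compound 2 to compound 4 (1.27 log units; beyond the scatter)) and also replaces 2-bromo-4-isopropylphenyl (a 20-fold higher number from compound 1 to compound 4 (1.30 log units; beyond the scatter)). Among these compounds, then, the change in the number follows the group on the aromatic nitrogen and not the amine.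

Going by these compounds, whether butyl(ethyl)amino would also match (cyclopropylmethyl)(propyl)amino with 2,4,6-trimethylphenyl on the aromatic nitrogen stays open, so the amine's silence may hold only for the 2,4,6-trimethylpyridin-3-yl series. Also open, on these data alone, is how a diethylamino group or a morpholine at the amine position, or a methoxy group in place of one methyl on the 2,4,6-trimethylpyridin-3-yl, would read in this assay.

No measurement given here bears on what lies behind the large steps at the aromatic nitrogen.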